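A few compounds are considered here, and "the series" means these few. Any claim that something is new, unique, unknown or untested is made for them only; others in the source may bear on it.

Measured in a functional assay on A549 cells (Homo sapiens) for cytotoxicity, read by MTT assay, with a stated time of 48 h; a lower number here means a stronger inhibitor, a higher number a weaker inhibitor:
- compound 1 `Cc1ccc(S(=O)(=O)/N=C(/CCNC2=CC(=O)c3ccccc3C2=O)Nc2cccc(C(F)(F)F)c2)cc1` gives 78500 nM
- compound 2 `Cc1ccc(S(=O)(=O)/N=C(/CCNC2=CC(=O)c3ccccc3C2=O)Nc2ccc(F)c(F)c2)cc1` gives 16700 nM
- compound 3 `COc1cc(N/C(CCNC2=CC(=O)c3ccccc3C2=O)=N\S(=O)(=O)c2ccc(C)cc2)cc(OC)c1OC` gives 7940 nM

Compound 2 holds the middle of these three numbers: its nearest neighbour is compound 3, reached by a 2.1-fold lower number from compound 2 to compound 3 (0.32 log units; beyond the scatter), and its furthest is compound 1, from which a 4.7-fold lower number from compound 1 to compound 2 (0.67 log units; beyond the scatter) leads to compound 2. Compound 4 `Cc1ccc(S(=O)(=O)/N=C(/CCNC2=CC(=O)c3ccccc3C2=O)NC2CCCCC2)cc1` differs from compound 2 by cyclohexyl in place of 3,4-difluorophenyl on an amine nitrogen. Among the compounds with values here, none of the measured steps bears directly on this change: a 4.7-fold lower number from compound 1 to compound 2 (0.67 log units; beyond the scatter), a 9.9-fold lower number from compound 1 to compound 3 (1.00 log units; beyond the scatter) and a 2.1-fold lower number from compound 2 to compound 3 (0.32 log units; beyond the scatter) all exchange one substituted aromatic ring for another on the same amine nitrogen, whereas compound 4 gives up the aromatic ring altogether. Those steps show that the group on this nitrogen shifts the number by modest amounts in either direction, so a modest step is plausible here too, but its direction cannot be read from the data. Compound 4 is therefore expected to stand near compound 2, with a 1.2-fold higher number from compound 2 to compound 4 (0.08 log units; within the scatter), and its estimated value is 20000 nM, within a range from 6000 nM to 70000 nM.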

Compound 4, half-maximal inhibitory concentration: 14700 nM
Compound 4: the middle estimate sits 1.4-fold (0.13 log units) above what was measured; the range from low to high includes it.
By their numbers in this assay, from the lowest: compounds 3, 4 and 2 (each within the scatter of the next, the first and the last beyond it); then compound 1.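

In this assay, giving up the aromatic ring on the amine nitrogen does not by itself separate compound 4 from two of the aromatic compounds: cyclohexyl stands within the scatter of 3,4-difluorophenyl, a 1.1-fold lower number from compound 2 to compound 4 (0.06 log units; within the scatter), and of 3,4,5-trimethoxyphenyl, a 1.9-fold higher number from compound 3 to compound 4 (0.27 log units; within the scatter). Only the 3-(trifluoromethyl)phenyl compound stands apart, a 5.3-fold lower number from compound 1 to compound 4 (0.73 log units; beyond the scatter), so among these four compounds an aromatic ring at this place is not required for the lower numbers, and compound 1 is the outlier. No measurement at hand explains why compound 1 differs.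

The compounds shown leave open how a straight alkyl chain, a benzyl group or a pyridine ring on this nitrogen would compare. They also leave open whether a cyclopentyl ring would stay with compound 4.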